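A Thiophene-Bearing Amine Replaces the Hydroxyindanyl Group

The compounds below may be only part of what the source reports. "The series", "measured", "known", "first", "only" and "open" are said of these compounds alone.

Compound 3 `O[C@@H]1Cc2ccccc2[C@H]1NC1CCN(CCCc2c[nH]c3ccc(-n4cnnc4)cc23)CC1` gives 13 nM in an assay on CHO cells for agonist activity at 5-hydroxytryptamine receptor 1D (Homo sapiens), read by GTPgammaS binding; on this read-out lower numbers stand for an effect already at smaller amounts and higher numbers for an effect only at larger amounts of compound. On that number compound 3 stands level with compound 1 `C[C@@H](NC1CCN(CCCc2c[nH]c3ccc(-n4cnnc4)cc23)CC1)c1ccccc1`, which gives 13 nM, and the two together form the highest of the three values measured; the step of no change at the digits printed from compound 1 to compound 3 (within the scatter) confirms this. The lowest number belongs to compound 2 `CC(C)=CCN(C)C1CCN(CCCc2c[nH]c3ccc(-n4cnnc4)cc23)CC1`, which gives 1.8 nM, so that a 7.2-fold higher number from compound 2 to compound 3 (0.86 log units; beyond the scatter) and a 7.2-fold lower number from compound 1 to compound 2 (0.86 log units; beyond the scatter).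

Compound 4 `CN(Cc1cccs1)C1CCN(CCCc2c[nH]c3ccc(-n4cnnc4)cc23)CC1` has not yet been measured. Its structure differs from compound 3 in one place: methyl((thiophen-2-yl)methyl)amino in place of (2-hydroxy-2,3-dihydro-1H-inden-1-yl)amino on a saturated ring carbon. Among the measured compounds shown here, two measured steps bear on this change. In both, the amine on the saturated ring carbon lost its hydrogen-bond donor and gained a methyl, and in both the number fell, as seen in a 7.2-fold lower number from compound 1 to compound 2 (0.86 log units; beyond the scatter) and in the reverse of a 7.2-fold higher number from compound 2 to compound 3 (0.86 log units; beyond the scatter). The entering methyl((thiophen-2-yl)methyl)amino group shares these counted features with the group of compound 2, though it is not the same group, so the full size of that step need not repeat. A modest fall beyond the scatter is therefore expected, namely a 3.7-fold lower number from compound 3 to compound 4 (0.57 log units; beyond the scatter). Compound 4 is accordingly estimated at 3.5 nM, with a likely range from 1.2 nM to 10 nM.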

Compound 4, half-maximal effective concentration: 3.5 nM
Compound 4: the middle estimate sits on the measured number at the digits printed; the measured number falls inside the stated range.
By their numbers in this assay, from the lowest: compounds 2 and 4 (each within the scatter of the next); then compounds 1 and 3 (each within the scatter of the next).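

The steps of a 3.7-fold lower number from compound 3 to compound 4 (0.57 log units; beyond the scatter) and a 3.7-fold lower number from compound 1 to compound 4 (0.57 log units; beyond the scatter) show that in this assay the lower numbers on this saturated ring carbon are not confined to the methyl(3-methylbut-2-en-1-yl)amino group of compound 2: methyl((thiophen-2-yl)methyl)amino, with one five-membered aromatic ring and no hydrogen-bond donor, also gives a number beyond the scatter from both compounds that keep the amine hydrogen. The step of a 1.9-fold higher number from compound 2 to compound 4 (0.29 log units; within the scatter) lies within the scatter, so thiophen-2-yl and 2-methylprop-1-en-1-yl cannot be told apart on the saturated chain carbon bound to the amine nitrogen. Among these four compounds, none of which goes against the pattern, the two methylated amines stand lower than the two that keep the amine hydrogen, yet no measured evidence here explains that separation.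

No pair shown changes the methyl on the amine nitrogen without also changing the group beyond it, so the share of each remains open. A plain (thiophen-2-yl)methylamino group would separate the two, and a methyl(benzyl)amino group would show whether a six-membered aromatic ring of carbon only fits this pattern.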